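Compound 3 to compound 4: working notes on solubility

This account rests on a few compounds, and the source may have more. Where it says the series, first, only, none or still open, it means among the compounds named here.

Compound 1 `O=C(O)COc1ccc([C@H]2CC[C@]3(CC2)OOC2(O3)C3CC4CC(C3)CC2C4)cc1Cl`: < 3.1 ug/mL (a limit)
Compound 2 `O=C(O)c1cccc([C@H]2CC[C@]3(CC2)OOC2(O3)C3CC4CC(C3)CC2C4)c1`: < 1.6 ug/mL (a limit)
Compound 3 `O=C(O)c1cc([C@H]2CC[C@]3(CC2)OOC2(O3)C3CC4CC(C3)CC2C4)ccc1O`: < 1.6 ug/mL (a limit)

In a physicochemical assay for solubility, read by nephelometry, in phosphate buffer, measured as kinetic solubility, with a stated time of 30 min, at pH 6.5 (a higher number here means a more soluble compound, a lower number a less soluble compound), compound 3 gives < 1.6 ug/mL, which is a limit, and it stands at the limit of < 1.6 ug/mL in this assay, at which 2 of the 3 values shown sit. Compound 4 `O=C(O)COc1ccc([C@H]2CC[C@]3(CC2)OOC2(O3)C3CC4CC(C3)CC2C4)cc1C(=O)O` differs from compound 3 by carboxymethyl in place of hydrogen on an oxygen on an aromatic ring, that is, hydroxy to carboxymethoxy. Among the measured compounds shown here, the one measured step that bears on this is a step that the two limits leave unreadable from compound 2 to compound 3, and it offers no size to carry over. Compound 1 also carries carboxymethoxy, yet it stands only at the limit of < 3.1 ug/mL in this assay, at which 1 of the 3 values shown sits. A small upward change is therefore expected, with wide uncertainty, as an at least 3.1-fold higher number from compound 3 to compound 4 (0.49 log units; beyond the scatter). For compound 4 the estimated value is 5 ug/mL, with an expected range of 1.5 ug/mL to 40 ug/mL.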

Compound 4, solubility: < 3.1 ug/mL
Compound 4: a limit, no number (the forecaster's own chance of this, stated with the estimate: 40%); at least 1.6-fold (0.20 log units) between middle value and limit.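

In this assay compound 4 gives < 3.1 ug/mL, a limit, so its steps from compound 1, compound 2 and compound 3 cannot be read. The compounds shown leave open the actual solubility of all four, each known only as a limit.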